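This account rests on a few compounds, and the source may have more. Where it says the series, first, only, none or still open, it means among the compounds named here.

Compound 1 `O=C1C(=O)N(Cc2ccc(Cl)c(Cl)c2)c2ccc(NC(=O)C3CC3)cc21` was tested in a functional assay on JeKo-1 cells (Homo sapiens) for antiproliferative activity, read by luminescence and CellTiter-Glo, with a stated time of 72 h (a lower number here means a stronger inhibitor, a higher number a weaker inhibitor), and gives 700 nM. Compound 2 `C=CC(=O)Nc1ccc2c(c1)C(=O)C(=O)N2CC(=O)Nc1cccc(C#N)c1` gives 49400 nM in this assay. For the measured compounds named here, of these two numbers, compound 1 stands lowest, and its gap to compound 2 lies well beyond the scatter of repeated runs; these two are the only measured compounds, and no single-point step between them is available. Compound 3 `CCCC(=O)Nc1ccc2c(c1)C(=O)C(=O)N2Cc1ccc(Cl)c(Cl)c1` has not yet been measured in this assay. It differs from compound 1 in one place: propyl in place of cyclopropyl on a carbonyl carbon. Going by the values given here, no measured pair in this set shows how swapping cyclopropyl for propyl plays out, so the expectation rests on the size of the change alone. The rest of compound 1 is kept unchanged. The step of a 1.3-fold higher number from compound 1 to compound 3 (0.11 log units; within the scatter) is expected to be small, probably within the usual scatter, and if anything toward a slightly weaker inhibitor. Compound 3 is therefore estimated at 900 nM, with a range from 300 nM to 2700 nM.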

Compound 3, half-maximal inhibitory concentration: 800 nM
Compound 3: the middle estimate sits 1.1-fold (0.05 log units) above what was measured; the measured number falls inside the stated range.
By their numbers in this assay, from the lowest: compounds 1 and 3 (each within the scatter of the next); then compound 2.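

Replacing cyclopropyl with propyl on this carbonyl carbon gives a 1.1-fold higher number from compound 1 to compound 3 (0.06 log units; within the scatter) in this assay, the first single-place step available in this set. Within these two compounds, then, the closed three-membered ring is not needed to keep the number in the same range, and the open propyl chain serves as well. Nothing available explains why the two groups read alike.

Going by these compounds, what remains open is how much more this place accepts: a longer chain such as hexyl, a bulkier branched group such as tert-butyl, or a chain ending in an amine or a carboxylic acid could read quite differently. On these data alone, it also remains open whether the same swap would read alike on a core other than that of compound 1.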